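Swapping the triazole substituent: from amide chain to nitrophenyl

This account rests on a few compounds, and the source may have more. Where it says the series, first, only, none or still open, it means among the compounds named here.

Of the compounds shown here, three built on the same core have been tested in a functional assay on DU-145 cells (Homo sapiens) for inhibition, read by MTT assay, with a stated time of 24 h; a higher number here means a weaker inhibitor, a lower number a stronger inhibitor. Compound 1 `CCOC(=O)C1=Cc2ccccc2OC1(OCc1cn(CC(=O)Nc2ccc(OC)cc2)nn1)C(F)(F)F` gives 32700 nM in this assay, the lowest of the two numbers recorded. Compound 3 `O=C(O)C1=Cc2ccccc2OC1(OCc1cc(-c2ccc(F)cc2)no1)C(F)(F)F` gives 168000 nM in this assay, a higher number than compound 1 by a gap beyond the usual scatter. Compound 2 `CCOC(=O)C1=Cc2ccccc2OC1(OCc1cc(-c2ccc([N+](=O)[O-])cc2)no1)C(F)(F)F` reaches only a limit of the assay, > 150000 nM in this assay, so no number is known for it; the limit of > 150000 nM in this assay, at which 1 of the 3 values shown sits, describes this limit. Among the measured compounds shown here, none of these pairs differ in just one place, so no single step has been measured.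

Compound 4 `CCOC(=O)C1=Cc2ccccc2OC1(OCc1cn(-c2ccc([N+](=O)[O-])cc2)nn1)C(F)(F)F` has not yet been tested. It differs from compound 1 in one place: 4-nitrophenyl in place of ((4-methoxyphenyl)carbamoyl)methyl on an aromatic nitrogen. For the measured compounds named here, with no measured step to lean on, a weakening step from compound 1 to compound 4 is expected, a 2.1-fold higher number from compound 1 to compound 4 (0.33 log units; beyond the scatter), beyond the scatter but not certain. Compound 4 is therefore expected to give about 70000 nM in this assay, most likely between 25000 nM and 200000 nM.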

Compound 4, half-maximal inhibitory concentration: > 150000 nM
Compound 4 was reported as a limit; the forecaster's own chance of this, stated with the estimate: 35%; middle value at least 2.1-fold (0.33 log units) from the limit.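

In this assay compound 4 gives > 150000 nM, which is a limit of the assay and not a number. Among the compounds shown here, this still yields the first single change that can be read on this core: 4-nitrophenyl in place of ((4-methoxyphenyl)carbamoyl)methyl on the aromatic nitrogen gives an at least 4.5-fold higher number from compound 1 to compound 4 (0.66 log units; beyond the scatter), so what this nitrogen carries clearly matters, and here the exchange weakens inhibition. The limit is also no rarity among these compounds: the limit of > 150000 nM in this assay, at which 2 of the 4 values shown sit.

The compounds shown do not tell whether losing the amide chain or bringing in the 4-nitrophenyl counts for more, and the full size of the step stays unknown. Going by these compounds, how a plain phenyl, a 4-aminophenyl or a longer chain ending in the same amide would read on this nitrogen also stays open.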